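The source may report more compounds than this note shows. Statements on the series, on what has been measured and on what is new or still open speak of the compounds shown alone.

In a functional assay on HCT-116 cells (Homo sapiens) for antiproliferative activity, read by MTT assay, with a stated time of 72 h (a lower number here means a stronger inhibitor, a higher number a weaker inhibitor), compound 1 `O=C(CCc1cccc2c1B(O)OC2)Nc1cccc(-c2cccc(F)c2)c1` gives 460 nM and compound 2 `O=C(CCc1cccc2c1B(O)OC2)Nc1cccc(-c2ccc(F)cc2)c1` gives 550 nM on the same read-out. Compound 3 `O=C(CCc1cccc2c1B(O)OC2)Nc1cccc(-c2cccc(C(F)(F)F)c2)c1` gives 580 nM and stands level with both of them, since a 1.3-fold higher number from compound 1 to compound 3 (0.10 log units; within the scatter) and a 1.1-fold higher number from compound 2 to compound 3 (0.02 log units; within the scatter) stay within the scatter.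

The next compound is compound 4 `N#Cc1cccc(-c2cccc(NC(=O)CCc3cccc4c3B(O)OC4)c2)c1`, which differs from compound 3 in one place: cyano in place of trifluoromethyl on an aromatic carbon. In words, this is cyano in place of trifluoromethyl on an aromatic carbon, meta to a large group, so 3-(trifluoromethyl)phenyl becomes 3-cyanophenyl.

The closest measured change is at the same place, trifluoromethyl in place of fluoro, and it amounts to a 1.3-fold higher number from compound 1 to compound 3 (0.10 log units; within the scatter) without leaving the scatter. The change from 3-fluorophenyl to 4-fluorophenyl, a 1.2-fold higher number from compound 1 to compound 2 (0.08 log units; within the scatter), also moves the number by no more than the scatter. Within the data shown here, no measured compound in this set carries a cyano group, so the evidence for this group is indirect. All three measured changes on this outer ring are small, so no step beyond the scatter is expected in this assay, and no direction is favoured. The expected change is a 1.1-fold lower number from compound 3 to compound 4 (0.02 log units; within the scatter) and it remains an estimate until measured. For compound 4 the estimated value is 550 nM with an expected range from 280 nM to 1100 nM in this read-out.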

Compound 4, half-maximal inhibitory concentration: 140 nM
The estimate for compound 4 lay 3.9-fold (0.59 log units) above the measured number, outside the stated range (below it).
By their numbers in this assay, from the lowest: compound 4; then compounds 1, 2 and 3 (each within the scatter of the next).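

In this assay, among these compounds, the substituent on this outer ring now matters: cyano in place of trifluoromethyl gives a 4.1-fold lower number from compound 3 to compound 4 (0.62 log units; beyond the scatter), the first step beyond the scatter. The other two comparisons agree, with cyano in place of fluoro giving a 3.3-fold lower number from compound 1 to compound 4 (0.52 log units; beyond the scatter) and 3-cyanophenyl in place of 4-fluorophenyl giving a 3.9-fold lower number from compound 2 to compound 4 (0.59 log units; beyond the scatter), so compound 4 stands apart from compounds 1, 2 and 3, which remain level with one another. This position is therefore not indifferent to its substituent, as the earlier compounds alone could have suggested, although nothing measured here accounts for the step.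

The compounds shown leave open whether this step is particular to cyano or would also appear with a carboxamide or a methyl ester on the same aromatic carbon. They also leave open whether the lower number in this cell read-out reflects action on one specific target or a more general effect on the cells.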